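The source may report more compounds than this note shows. Statements on the series, on what has been measured and on what is new or still open speak of the compounds shown alone.

Measured so far in an ADME assay on HepG2 cells (Homo sapiens) for cytotoxicity, read by CellTiter-Glo and resazurin assay, with a stated time of 72 h; on this read-out higher numbers stand for an effect only at larger amounts of compound and lower numbers for an effect already at smaller amounts:
compound 1, `CCOC(=O)CCCCCOc1cccc(CN(C(=O)c2ccc(-c3cccc4ccccc34)cc2)C(C)C)c1`, > 26000 nM
compound 2, `CCOC(=O)CCCCCOc1cccc(CN(C(=O)c2ccc(-c3cccc(OCc4ccccc4)c3)cc2)C(C)C)c1`, > 26000 nM

In this assay compound 1 reaches only a limit of the assay, > 26000 nM. Compound 2 likewise reaches only a limit of the assay, > 26000 nM. Going by the values given here, both values sit at the same limit, (the limit of > 26000 nM in this assay, at which 2 of the 2 values shown sit), so no step between them can be counted and the pair shows nothing beyond that neither produces an effect within the tested range.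

The next compound is compound 3, `CCOC(=O)CCCCCOc1cccc(CN(C(=O)c2ccc(-c3cccc(OC)c3)cc2)C(C)C)c1`. It differs from compound 2 in one place: hydrogen in place of phenyl on a saturated chain carbon bound to an oxygen on an aromatic ring, that is, benzyloxy becomes methoxy. Among the compounds with values here, with both measured values sitting at the limit, there is no measured step to build on, and the expectation is that compound 3 will again reach only the limit rather than a number. The estimated step from compound 2 to compound 3 is a step that the limit leaves unreadable from compound 2 to compound 3, within the scatter. Compound 3 is expected at 30000 nM, in the range 10000 nM to 100000 nM.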

Compound 3, half-maximal effective concentration: > 21000 nM
Compound 3 ended at the assay's limit; the forecaster's own chance of this, stated with the estimate: 80%; the middle value does not contradict the limit.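

In this assay, going by these compounds alone, compound 3 gives > 21000 nM, which is a limit of the assay, so no step from compound 1 or compound 2 to compound 3 can be read. The compounds shown leave open at what concentration, if any, each would produce an effect.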